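A few compounds are considered here, and "the series" means these few. Any claim that something is new, unique, unknown or untested is made for them only; others in the source may bear on it.

Values in a functional assay on HOP-62 cells (Homo sapiens) for inhibition, read by sulforhodamine B assay (a higher number here means a weaker inhibitor of growth, a lower number a stronger inhibitor of growth), so far
Compound 1 `COc1ccc(-c2ccc(-c3ccc(-c4nc5cc(C)ccc5[nH]4)cc3)cc2)cc1OC` gives 2120 nM
Compound 2 `Fc1ccc(-c2ccc(-c3ccc(-c4nc5ccccc5[nH]4)cc3)cc2)cc1` gives 39300 nM

Of these two, compound 2 (39300 nM) holds the higher number, beyond the scatter from compound 1. Compound 3 `COc1ccc(-c2ccc(-c3ccc(-c4nc5ccccc5[nH]4)cc3)cc2)cc1` has not yet been measured. It differs from compound 2 by methoxy in place of fluoro on an aromatic carbon with methoxy in place of fluoro on an aromatic carbon. Among the compounds with values here, no single-place step has been measured. The expectation rests only on compound 1 (2120 nM), which also carries methoxy groups but differs from compound 2 in more than one place. The expected change is a moderate move toward a lower number, estimated as a 3.6-fold lower number from compound 2 to compound 3 (0.55 log units; beyond the scatter) and beyond the scatter. Compound 3 is expected at 11000 nM (estimated range 3000 nM to 40000 nM).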

Compound 3, concentration for 50% growth inhibition: 100000 nM
Compound 3: middle estimate off by 9.1-fold (0.96 log units), on the low side, and the stated range ends below it.
By their numbers in this assay, from the lowest: compound 1; then compound 2; then compound 3.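

In this assay, within the data shown here, the change from 4-fluorophenyl to 4-methoxyphenyl gives a 2.5-fold higher number from compound 2 to compound 3 (0.41 log units; beyond the scatter), the first direct reading of this swap at this position, and it goes toward weaker growth inhibition. A methoxy group in place of fluoro therefore brings no gain here when taken alone, so the lower number of compound 1 cannot be credited to that single change. Nothing shown explains the step.

Still open, going by these compounds, is how the second methoxy group and the methyl group of compound 1 each contribute. Also open, on these data alone, is how an amine or a carboxylic acid would behave at this position.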